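The compounds below may be only part of what the source reports. "The series", "measured", "known", "first", "only" and "open" are said of these compounds alone.

Going by the values given here, compound 1 `CCC(C(=O)N1CCN(c2cccc(Cl)c2)CC1)N1C(=O)CCC1=O` and compound 2 `CC(C(=O)N1CCN(c2ccccc2C(F)(F)F)CC1)N1C(=O)CCC1=O` share a core but differ in more than one place, so no single-place step is counted between them. In a functional assay on the whole organism (strain Swiss) with Mus musculus as the target, in the maximal electroshock model, with a stated time of 0.25 h, at a dose of 300 mg/kg by the intraperitoneal route (on this read-out lower numbers stand for a weaker effect and higher numbers for a stronger effect at the one dose given), compound 1 gives 75%, and compound 2 gives 100%. Compound 1 thus stands lowest of the two numbers shown, with compound 2 lying beyond the scatter above it. Compound 3 `CCC(C(=O)N1CCN(c2ccccc2F)CC1)N1C(=O)CCC1=O` has not yet been measured in this assay. The change from compound 1 to compound 3 is 2-fluorophenyl in place of 3-chlorophenyl on an amine nitrogen in a ring. Among the compounds with values here, with no measured step between compounds that differ in one place, the size of this step in this assay is open; the one measured comparison mixes two changes and cannot guide it. A step no larger than the scatter, or at most a modest rise, is expected. The estimate means a step of a number 5 percentage points higher from compound 1 to compound 3 (within the scatter) in this assay. Compound 3 is expected to give 80%, within 50% to 100%.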

Compound 3, a percentage reported as activity, at one dose (the size of the read-out at that dose, not a potency): 100%
The estimate for compound 3 lay 20 percentage points below the measured number; the range from low to high includes it.
By their numbers in this assay, from the lowest: compound 1; then compounds 2 and 3 (each within the scatter of the next).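

In this assay, going by these compounds alone, replacing 3-chlorophenyl with 2-fluorophenyl on the amine nitrogen in the ring gives the first single-place reading at this position: a number 25 percentage points higher from compound 1 to compound 3 (beyond the scatter), with no change in the count of heavy atoms, hydrogen-bond donors or acceptors, or in net charge. The halogen and its place on the phenyl ring change together in this step, so this comparison cannot separate the two. No measurement on hand bears on the origin of the step.

The compounds shown leave open how 2-chlorophenyl, 3-fluorophenyl or an unsubstituted phenyl would read on the same nitrogen, and these groups would separate the halogen from its place. Also open, going by these compounds, is how the step would read at other doses, as this read-out gives the size of the effect at one dose and not a potency.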